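Amide variation on a pyridine-linked aryl series

The source may report more compounds than this note shows. Statements on the series, on what has been measured and on what is new or still open speak of the compounds shown alone.

Measured so far:
compound 1, `CNC(=O)/C=C/c1ccncc1-c1ccc2cc[nH]c2c1`: 10400 nM
compound 2, `O=C(/C=C/c1ccncc1-c1ccc2cc[nH]c2c1)N1CCOCC1`: > 30000 nM (a limit of the assay, not a number)
compound 3, `O=C(CCc1ccncc1-c1ccc2ccccc2c1)N1CCOCC1`: > 30000 nM (a limit of the assay, not a number)

In a functional assay on HCT-116 cells (Homo sapiens) for inhibition, read by MTT assay, with a stated time of 72 h (a higher number here means a weaker inhibitor of growth, a lower number a stronger inhibitor of growth), compound 1 gives 10400 nM. For compound 2 the result in this assay is > 30000 nM, which is a limit of the assay and not a number. For compound 3 the result in this assay is likewise a limit and not a number, > 30000 nM.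

Within the data shown here, the one counted change among the measured compounds is methylamino in place of morpholin-4-yl on a carbonyl carbon, and it gave an at least 2.8-fold lower number from compound 2 to compound 1 (0.46 log units; beyond the scatter). The size of that step is bounded by the limit of > 30000 nM in this assay, at which 2 of the 3 values shown sit, so only its lower end is known.

Compound 4, `CNC(=O)CCc1ccncc1-c1ccc2ccccc2c1`, is not yet measured in this assay. It differs from compound 3 by methylamino in place of morpholin-4-yl on a carbonyl carbon. Among the measured compounds shown here, this is the same kind of change as the one from compound 2 to compound 1, though not the same: there the carbonyl carbon's other neighbour is a double-bonded chain carbon, here it is a saturated chain carbon. How the core of compound 3 differs from the core of compound 2 is not broken down here.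

The expectation for compound 4 rests on the step from compound 2 to compound 1, an at least 2.8-fold lower number from compound 2 to compound 1 (0.46 log units; beyond the scatter), carried over to a core whose own value for compound 3 is only a limit. Compound 4 is therefore expected to show an at least 2.0-fold lower number from compound 3 to compound 4 (0.30 log units; that floor lies within the scatter). For compound 4 in this assay the estimate is 15000 nM, with an expected range from 5000 nM to 45000 nM.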

Compound 4, concentration for 50% growth inhibition: 19300 nM
For compound 4 the middle estimate is 1.3-fold (0.11 log units) below the measured one; the range from low to high includes it.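

In this assay, methylamino in place of morpholin-4-yl on a carbonyl carbon whose other neighbour is a saturated chain carbon gives an at least 1.5-fold lower number from compound 3 to compound 4 (0.19 log units; that floor lies within the scatter), so the lower number seen on the first core also appears on this second core, although the floor of this step does not by itself establish a change beyond the usual scatter. Compound 3 carries a limit of the assay and not a number, so only the lower end of this step is known, and the same applies to the earlier step: the limit of > 30000 nM in this assay, at which 2 of the 4 values shown sit.

Set side by side, the two steps agree in direction but do not show that the size of the change carries from one core to the other: the same change on two cores in this assay, an at least 2.8-fold lower number (0.46 log units; beyond the scatter) from compound 2 to compound 1 and an at least 1.5-fold lower number (0.19 log units; that floor lies within the scatter) from compound 3 to compound 4; the limit leaves it open whether they differ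

The cores of compound 1 and compound 4 differ in more than one place, so the compounds shown do not separate the contribution of the chain from that of the rest of the core. Also open, going by these compounds, is how dimethylamino, which has no amide hydrogen, or piperidin-1-yl, which has no ring oxygen, would read on the same carbonyl carbon on either core.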